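Removing One Chloro from the Anilino Ring

The source may report more compounds than this note shows. Statements on the series, on what has been measured and on what is new or still open speak of the compounds shown alone.

Two measured compounds share one core and differ only in the aryl group on the amine nitrogen. Compound 1 `CN1CCN(CCCOc2cccc3nc(Nc4ccc(Cl)c(F)c4)ccc23)CC1` in a functional assay on OVCAR-8 cells (Homo sapiens) for inhibition, read by sulforhodamine B assay, with a stated time of 48 h (a lower number here means a stronger inhibitor of growth, a higher number a weaker inhibitor of growth), gives 2020 nM. Compound 2 `CN1CCN(CCCOc2cccc3nc(Nc4cc(Cl)cc(Cl)c4)ccc23)CC1` gives 1940 nM in this assay; it stands at the lower of the two numbers, but its gap to compound 1 lies within the scatter. The step of a 1.0-fold lower number from compound 1 to compound 2 (0.02 log units; within the scatter) shows that swapping one substituted aryl group for another changed little. Compound 3 `CN1CCN(CCCOc2cccc3nc(Nc4cccc(Cl)c4)ccc23)CC1` differs from compound 2 by hydrogen in place of chloro on an aromatic carbon. Going by the values given here, only that one measured step bears on the question, and it concerned a different exchange, so there is no direct precedent for deleting a single chloro group; the closest evidence is that two aryl patterns gave numbers within the scatter of each other. The step from compound 2 to compound 3 is therefore expected to be a 1.0-fold higher number from compound 2 to compound 3 (0.01 log units; within the scatter), not beyond the scatter. Compound 3 is estimated at 2000 nM, with a range from 900 nM to 4500 nM.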

Compound 3, concentration for 50% growth inhibition: 1900 nM
Compound 3: middle estimate off by 1.1-fold (0.02 log units), on the high side; the measured number falls inside the stated range.
By their numbers in this assay, from the lowest: compounds 3, 2 and 1 (each within the scatter of the next).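

Deleting a single chloro group from the 3,5-dichlorophenyl ring now has a direct measurement: in this assay the step is a 1.0-fold lower number from compound 2 to compound 3 (0.01 log units; within the scatter) and so stays within the scatter. The 3-chlorophenyl group also stands level with the 4-chloro-3-fluorophenyl group, as a 1.1-fold lower number from compound 1 to compound 3 (0.03 log units; within the scatter) shows, so the three aryl patterns shown all lie within the scatter of one another. Nothing shown explains why these exchanges leave the number in place.

Going by these compounds, it remains open whether removing the last chloro group to leave a plain phenyl ring would also stay within the scatter. On these data alone, it is equally open whether a methoxy group, a nitrile or an amine in place of the chloro group would shift the number in this assay beyond it.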